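Amide nitrogen variation: expectation for compound 4

This account rests on a few compounds, and the source may have more. Where it says the series, first, only, none or still open, it means among the compounds named here.

Measured so far:
- compound 1 `COc1ccc(CNC(=O)/C=C/c2coc3cc(O)ccc3c2=O)cc1`: in a functional assay on HeLa cells (Homo sapiens) for inhibition, read by MTT assay, with a stated time of 48 h (on this read-out lower numbers stand for stronger inhibition and higher numbers for weaker inhibition), compound 1 gives > 100000 nM, a limit of the assay and not a number.
- compound 2 `COc1ccc2c(=O)c(/C=C/C(=O)Nc3cc(C)ccc3C)coc2c1`: in this assay compound 2 gives 58400 nM.
- compound 3 `COc1ccc2c(=O)c(/C=C/C(=O)NCc3cccc(F)c3)coc2c1`: in this assay compound 3 gives 17600 nM.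

Compound 3 stands lowest of the two numbers shown; its nearest neighbour is compound 2, the gap being a 3.3-fold lower number from compound 2 to compound 3 (0.52 log units; beyond the scatter). Compound 4 `COc1ccc2c(=O)c(/C=C/C(=O)Nc3ccccc3OC)coc2c1` differs from compound 3 by 2-methoxyphenyl in place of 3-fluorobenzyl on an amide-type nitrogen. Going by the values given here, the only measured step that bears on this is a 3.3-fold lower number from compound 2 to compound 3 (0.52 log units; beyond the scatter), in which 3-fluorobenzyl replaced 2,5-dimethylphenyl on the amide nitrogen and the number fell. Compound 4 moves back the other way, putting a phenyl-type group directly on that nitrogen, so for compound 4 a higher number than compound 3 is expected, about a 2.3-fold higher number from compound 3 to compound 4 (0.36 log units; beyond the scatter). The estimate for compound 4 in this assay is 40000 nM, with a range from 15000 nM to 100000 nM.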

Compound 4, half-maximal inhibitory concentration: > 100000 nM
Compound 4 ended at the assay's limit; the forecaster's own chance of this, stated with the estimate: 20%; at least 2.5-fold (0.39 log units) between middle value and limit.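

In this assay the change to 2-methoxyphenyl on the amide-type nitrogen gives an at least 5.6-fold higher number from compound 3 to compound 4 (0.75 log units; beyond the scatter), so a second group set directly on that nitrogen also stands above 3-fluorobenzyl. Between the two groups set directly on the nitrogen, an at least 1.7-fold higher number from compound 2 to compound 4 (0.23 log units; that floor lies within the scatter) allows no order. The value of compound 4 is a limit of the assay and not a number, which leaves the true size of both steps unknown: the limit of > 100000 nM in this assay, at which 2 of the 4 values shown sit.

The step from compound 3 to compound 4 changes both the link to the ring and the ring's substituent, and the compounds shown do not separate the two. Going by these compounds, how an unsubstituted benzyl or a 2-phenylethyl chain on this nitrogen would read also stays open.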